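From 2-vinylphenyl to 1,3-thiazol-2-yl on the shared core

The source may report more compounds than this note shows. Statements on the series, on what has been measured and on what is new or still open speak of the compounds shown alone.

compound 1 `COC1=C(C)C(=O)/C(=C(O)/C=C/c2ccc(F)cc2)C(=O)C1(C)C` gives 2.7 ug/mL here
compound 2 `COC1=C(C)C(=O)/C(=C(O)/C=C/c2c(C)cccc2C)C(=O)C1(C)C` gives 2.1 ug/mL here
compound 3 `C=Cc1ccccc1/C=C/C(O)=C1/C(=O)C(C)=C(OC)C(C)(C)C1=O` gives 1.1 ug/mL here

All three values come from a functional assay on KB cells (Homo sapiens) for cytotoxicity (on this read-out higher numbers stand for an effect only at larger amounts of compound and lower numbers for an effect already at smaller amounts), and differ only in the group on the chain. Compound 3 stands clearly apart from compound 1, with a 2.5-fold lower number from compound 1 to compound 3 (0.39 log units; beyond the scatter) as a modest step. It cannot be told apart from compound 2, as a 1.9-fold lower number from compound 2 to compound 3 (0.28 log units; within the scatter) shows, and a 1.3-fold lower number from compound 1 to compound 2 (0.11 log units; within the scatter) is no larger than the scatter either.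

Compound 4 `COC1=C(C)C(=O)/C(=C(O)/C=C/c2nccs2)C(=O)C1(C)C` carries 1,3-thiazol-2-yl in place of 2-vinylphenyl, on a double-bonded chain carbon bound to a double-bonded chain carbon (1,3-thiazol-2-yl in place of 2-vinylphenyl on a double-bonded chain carbon bound to a double-bonded chain carbon). Within the data shown here, all three measured steps are swaps at this same place, but no measured compound has a ring with hetero atoms there, so they bear on it only indirectly. Compound 3 has the 2-vinylphenyl group that now leaves, and replacing that group in the reverse sense of a 2.5-fold lower number from compound 1 to compound 3 (0.39 log units; beyond the scatter) suggests a modest move back to a higher number. On that basis, a 2.4-fold higher number from compound 3 to compound 4 (0.37 log units; beyond the scatter) is the expected step in this assay for this swap. Compound 4 is estimated at 2.6 ug/mL (expected range 1 ug/mL to 7 ug/mL).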

Compound 4, concentration for half-maximal effect: 3 ug/mL
Beside the measured number, compound 4's estimate is 1.2-fold (0.06 log units) below it; low and high end bracket the measured number.
By their numbers in this assay, from the lowest: compounds 3, 2, 1 and 4 (each within the scatter of the next, the first and the last beyond it).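

In this assay, the first ring with hetero atoms at this place, 1,3-thiazol-2-yl, cannot be told apart from two of the carbon-only aryl groups, as a 1.1-fold higher number from compound 1 to compound 4 (0.05 log units; within the scatter) and a 1.4-fold higher number from compound 2 to compound 4 (0.15 log units; within the scatter) show for the 4-fluorophenyl and 2,6-dimethylphenyl groups. Only 2-vinylphenyl differs clearly from it, with a 2.7-fold higher number from compound 3 to compound 4 (0.44 log units; beyond the scatter) as a modest step, so the spread at this place rests on compound 3 alone, and even that compound stays within the scatter of compound 2 while lying beyond it from compound 1 and compound 4. Nothing measured here explains that step.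

The compounds shown leave open whether the vinyl group by itself sets compound 3 apart, or whether an unsubstituted phenyl would sit with the other groups. They also leave open how a pyridine ring, an amine or a carboxylic acid would read at this place.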